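Adding a Benzyloxy Group to Compound 2

The source may report more compounds than this note shows. Statements on the series, on what has been measured and on what is new or still open speak of the compounds shown alone.

Compound 2 `CC/C(=C(/c1ccccc1)c1ccc(NC(=O)C(C)C)cc1)c1ccccc1` gives 28100 nM in a functional assay on HeLa cells (Homo sapiens) for inhibition, read by trypan blue exclusion, with a stated time of 72 h (on this read-out higher numbers stand for weaker inhibition of growth and lower numbers for stronger inhibition of growth), the higher of the two numbers seen; compound 1 `CC/C(=C(\c1ccccc1)c1ccc(NC(=O)C(C)C)cc1)c1ccc(OCc2ccccc2)cc1` gives 10200 nM in this assay. Compound 3 `CC/C(=C(/c1ccccc1)c1ccc(NC(=O)C(C)C)cc1)c1ccc(OCc2ccccc2)cc1` is reached from compound 2 by one change: benzyloxy in place of hydrogen on an aromatic carbon. For the measured compounds named here, no measured pair isolates this change, so the expectation rests on the two values at hand. Compound 1, which also carries a benzyloxy group, shows 10200 nM against compound 2 at 28100 nM, so a step toward a lower number beyond the scatter is expected. Compound 3 is therefore estimated at 10000 nM, within 4000 nM to 30000 nM, a step of a 2.8-fold lower number from compound 2 to compound 3 (0.45 log units; beyond the scatter).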

Compound 3, concentration for 50% growth inhibition: > 30000 nM
Compound 3 gave a limit, no number; the forecaster's own chance of this, stated with the estimate: 5%; at least 3.0-fold (0.47 log units) between middle value and limit.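

In this assay the result for compound 3 is a limit and not a number: the limit of > 30000 nM in this assay, at which 1 of the 3 values shown sits. Benzyloxy in place of hydrogen, para to a large group, gives an at least 1.0-fold higher number from compound 2 to compound 3 (0.02 log units; that floor lies within the scatter), so this change shows no lowering of the number with the double bond drawn E. Moving from the Z to the E configuration gives an at least 2.9-fold higher number from compound 1 to compound 3 (0.46 log units; beyond the scatter), a step that rests on configuration alone: the fact that compounds 1 and 3 differ only in the configuration as drawn.

From the compounds shown here alone, how far compound 3 lies past its limit stays open. So does whether a methoxy group or a dimethylaminoethoxy chain at this position would give a lower number in the E configuration.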